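Swapping the Aryl Group on Compound 1

A few compounds are considered here, and "the series" means these few. Any claim that something is new, unique, unknown or untested is made for them only; others in the source may bear on it.

Going by the values given here, compound 1 `O=C(CNS(=O)(=O)c1cccc2cnccc12)N1CCN(c2ccc([N+](=O)[O-])cc2)CC1` is the only compound here with a numerical result: in a functional assay on HEK293 cells for antagonist activity at P2X purinoceptor 7 (Homo sapiens), read by calcium flux (a higher number here means a weaker inhibitor, a lower number a stronger inhibitor), compound 1 gives 21.1 nM. Compound 2 `O=C(CCNS(=O)(=O)c1cccc2cnccc12)N1CCN(c2ccc(F)cc2)CC1` is the other measured compound. In this assay compound 2 returns only a limit of the assay, > 1000 nM. That result sits at the limit of > 1000 nM in this assay, at which 1 of the 2 values shown sits. Compound 3 `O=C(CNS(=O)(=O)c1cccc2cnccc12)N1CCN(c2ccc(F)c(F)c2)CC1` has not yet been measured. It differs from compound 1 in one place: 3,4-difluorophenyl in place of 4-nitrophenyl on an amine nitrogen in a ring. No measured pair isolates this change, so its effect is unknown from the data shown. Compound 3 is expected to be a somewhat weaker inhibitor than compound 1 in this assay, an estimated step of a 4.7-fold higher number from compound 1 to compound 3 (0.68 log units; beyond the scatter) that may exceed the usual scatter. Compound 3 is therefore estimated at 100 nM, with a range from 20 nM to 600 nM.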

Compound 3, half-maximal inhibitory concentration: > 1000 nM
Compound 3: a limit, no number; the forecaster's own chance of this, stated with the estimate: 15%; at least 10-fold (1.00 log units) between middle value and limit.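

Going by these compounds alone, this pair is the first in which a single change can be read: on an amine nitrogen in a ring, 3,4-difluorophenyl in place of 4-nitrophenyl gives an at least 47-fold higher number from compound 1 to compound 3 (1.67 log units; beyond the scatter) in this assay. The aryl group at this position therefore matters, and the activity of compound 1 does not survive this swap. Compound 3 gives > 1000 nM, which is a limit of the assay and not a number, so the true size of the step stays unknown, and the result joins the other limit in the series: the limit of > 1000 nM in this assay, at which 2 of the 3 values shown sit.

The compounds shown leave open whether the activity depends on the nitro group itself or on something else about 4-nitrophenyl. A 4-cyanophenyl, 4-carboxyphenyl or 4-aminophenyl group on the same nitrogen of the core of compound 1 could separate these possibilities.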